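The compounds below may be only part of what the source reports. "The series", "measured", "known", "first", "only" and "open" are said of these compounds alone.

Among the three compounds measured so far, compound 3 `CC(C)C[C@H](N)c1cc(C(F)(F)F)ccc1N1CCN(C(=O)CCc2csc3ccccc23)CC1` holds the lowest number in an assay on HEK293 cells for displacement of a labelled ligand from Melanocortin receptor 4 (Homo sapiens) (on this read-out higher numbers stand for weaker inhibition and lower numbers for stronger inhibition), where compound 3 gives 2300 nM. Compound 1 `CC(C)C[C@H](N)c1cc(C(F)(F)F)ccc1N1CCN(C(=O)CCc2ccc(S(C)(=O)=O)cc2)CC1` gives 4900 nM in this assay, and compound 2 `COc1cc(OC)c(OC)cc1CCC(=O)N1CCN(c2ccc(C(F)(F)F)cc2[C@@H](N)CC(C)C)CC1` gives 6100 nM. All three share one core and differ only in the aromatic group attached to the saturated chain carbon two bonds from the carbonyl carbon. Exchanging one six-membered aromatic group for another gave a 1.2-fold higher number from compound 1 to compound 2 (0.10 log units; within the scatter), whereas moving to the fused bicyclic group gave a 2.1-fold lower number from compound 1 to compound 3 (0.33 log units; beyond the scatter) and a 2.7-fold lower number from compound 2 to compound 3 (0.42 log units; beyond the scatter). Compound 4 `Cc1[nH]c2ccccc2c1CCC(=O)N1CCN(c2ccc(C(F)(F)F)cc2[C@@H](N)CC(C)C)CC1` keeps that core and differs from compound 3 by 2-methyl-1H-indol-3-yl in place of 1-benzothiophen-3-yl on a saturated chain carbon, two bonds along the chain from a carbonyl carbon. Within the data shown here, no measured step involves an indole, so the three steps above only suggest that a swap at this place moves the number modestly, if at all. The expected step is therefore a 1.2-fold lower number from compound 3 to compound 4 (0.06 log units; within the scatter), a small change in either direction. Compound 4 is expected to give 2000 nM in this assay, with a range from 700 nM to 6000 nM.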

Compound 4, inhibition constant: 1600 nM
Compound 4: middle estimate off by 1.3-fold (0.10 log units), on the high side, and the stated range covers the measured number.
By their numbers in this assay, from the lowest: compounds 4 and 3 (each within the scatter of the next); then compounds 1 and 2 (each within the scatter of the next).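

Swapping 1-benzothiophen-3-yl for 2-methyl-1H-indol-3-yl gives a 1.4-fold lower number from compound 3 to compound 4 (0.16 log units; within the scatter) in this assay, so this position accepts a second fused group even though sulfur gives way to nitrogen, a hydrogen-bond donor enters and the heavy-atom count rises. Set against the groups with a single six-membered ring, the indole gives a 3.8-fold lower number from compound 2 to compound 4 (0.58 log units; beyond the scatter) and a 3.1-fold lower number from compound 1 to compound 4 (0.49 log units; beyond the scatter), so among these four compounds both fused groups sit beyond the scatter of both single-ring groups. Nothing measured here explains why the fused groups give lower numbers.

On these data alone, the methyl and the indole hydrogen enter together, so their separate contributions remain unknown, and a plain 1H-indol-3-yl would be needed to pull them apart. As far as these compounds go, whether a naphthyl group or a longer chain would keep these numbers also remains open.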